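A few compounds are considered here, and "the series" means these few. Any claim that something is new, unique, unknown or untested is made for them only; others in the source may bear on it.

Measured so far:
compound 1, `FC(F)(F)c1ccc(Nc2nc(-c3ccc(Cl)cc3)cs2)cc1`, with 600 nM in an assay on isolated protein for inhibition of Polyunsaturated fatty acid 5-lipoxygenase (Homo sapiens), read by HPLC, with stated times of 15 min and 10 min; on this read-out lower numbers stand for stronger inhibition and higher numbers for weaker inhibition;
compound 2, `Oc1ccc(Nc2nc(-c3ccc(Cl)c(Cl)c3)cs2)cc1`, with 30 nM in this assay;
compound 3, `COc1ccccc1Nc1nc(-c2ccc(Cl)cc2)cs1`, with 2700 nM in this assay.

Among these three, compound 3 has the highest number, so it is the weakest inhibitor, and its gap to both others lies beyond the usual scatter. Compound 4, `Clc1ccc(-c2csc(Nc3ccccc3)n2)cc1`, is not yet measured. It differs from compound 3 in one place: hydrogen in place of methoxy on an aromatic carbon, so the aromatic ring attached to the shared core carries no substituent at all. For the measured compounds named here, no measured pair shows this exact change, so the size of the step can only be guessed from the three values. Removing the methoxy is expected to give a somewhat lower number, a step of a 3.0-fold lower number from compound 3 to compound 4 (0.48 log units; beyond the scatter), moving compound 4 toward compound 1. Compound 4 is estimated at 900 nM, within 300 nM to 3000 nM.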

Compound 4, half-maximal inhibitory concentration: 700 nM
Compound 4: the middle estimate sits 1.3-fold (0.11 log units) above what was measured; the range from low to high includes it.
By their numbers in this assay, from the lowest: compound 2; then compounds 1 and 4 (each within the scatter of the next); then compound 3.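

In this assay, hydrogen in place of methoxy on this aromatic carbon, ortho to a large group, gives a 3.9-fold lower number from compound 3 to compound 4 (0.59 log units; beyond the scatter), so in this pair the methoxy goes with weaker inhibition. Hydrogen in place of trifluoromethyl gives a 1.2-fold higher number from compound 1 to compound 4 (0.07 log units; within the scatter), which leaves compound 1 and compound 4 indistinguishable in this assay. No supporting measurement accounts for either step. Going by these compounds, whether fluorine, an amine or a longer ether chain on this ortho carbon would match hydrogen or behave like methoxy remains open. So does whether the methoxy step would hold with a second chlorine on the other ring.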